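A Methyl Added to a Fused Ring Core

A few compounds are considered here, and "the series" means these few. Any claim that something is new, unique, unknown or untested is made for them only; others in the source may bear on it.

Measured compounds:
compound 1 `CC(C)[C@H]1CCC2C(=O)CC(=O)C=C21` gives 2530 nM in an assay on isolated protein for inhibition of Toll-like receptor 4 (Homo sapiens), read by ELISA; a higher number here means a weaker inhibitor, a lower number a stronger inhibitor
compound 2 `O=C1C=C2CC[C@@H](NC(=O)OCc3ccccc3)CC2C(=O)C1` gives 560 nM in this assay
compound 3 `O=C1C=C2CCCCC2C(=O)CC1` gives 1850 nM in this assay

Compound 3 carries the bare shared core. Its number in this assay is the second highest of the three. Compound 1, which bears an isopropyl group on that core, lies nearest, and the two values fall within the scatter of one another, so nothing separates them. Compound 2, with a carbamate-bearing side group, lies furthest away with a lower number, a gap beyond the scatter.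

Compound 4 `C[C@H]1CCC2C(=O)CCC(=O)C=C2C1` has not yet been measured in this assay. It differs from compound 3 in one place: methyl in place of hydrogen on a saturated ring carbon. Among the measured compounds shown here, no measured pair shows this exact change, so the expectation rests on compound 1, which gives 2530 nM, and on compound 3, which gives 1850 nM. Those two values show that a small alkyl group on a saturated ring carbon of this core leaves the number essentially where it was. The step from compound 3 to compound 4 is therefore expected to be a 1.1-fold higher number from compound 3 to compound 4 (0.03 log units; within the scatter), with no movement beyond the scatter in either direction. Compound 4 is expected to give about 2000 nM in this assay, within a range of 900 nM to 4500 nM.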

Compound 4, half-maximal inhibitory concentration: 2660 nM
Beside the measured number, compound 4's estimate is 1.3-fold (0.12 log units) below it; the measured number falls inside the stated range.
By their numbers in this assay, from the lowest: compound 2; then compounds 3, 1 and 4 (each within the scatter of the next).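

Methyl in place of hydrogen on this saturated ring carbon, three ring bonds from the ring atom that bears a fused ring, gives a 1.4-fold higher number from compound 3 to compound 4 (0.16 log units; within the scatter) in this assay. Among the compounds shown here, this is the first direct reading on the shared core, since no two of the earlier compounds differed in one place. It shows that this single methyl, at this position, separates the two compounds by nothing that can be told from the scatter. Nothing available here offers a reason for this result.

Still open, as far as these compounds go, is whether a larger or different group on the same ring carbon, such as a longer chain, an amine or a carboxylic acid, would move the number beyond the scatter. One methyl says little about such groups, and only compounds carrying them at this position could settle the question.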